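The compounds below may be only part of what the source reports. "The series", "measured", "known", "first", "only" and "open" are said of these compounds alone.

Measured so far, in a physicochemical assay for solubility, read by turbidimetry, measured as kinetic solubility, at pH 7.4; on this read-out lower numbers stand for lower solubility and higher numbers for higher solubility:

Compound 1, `O=C(NCCCCc1ccccc1)c1cccc(C2SCC(=O)N2c2cccc(-c3c[nH]nn3)c2)c1`, gives 20000 nM.
Compound 2, `O=C(NCCCCn1cccn1)c1cccc(C2SCC(=O)N2c2ccccn2)c1`, gives 50000 nM.
Compound 3, `O=C(NCCCCc1ccccc1)c1cccc(C2SCC(=O)N2c2ccccn2)c1`, gives 20000 nM.

Compound 3 stands level with compound 1 at the digits shown, the two together forming the lowest numbers of the three; its nearest neighbour is compound 1, with no change at the digits printed from compound 1 to compound 3 (within the scatter), and the furthest is compound 2, from which the step is a 2.5-fold lower number from compound 2 to compound 3 (0.40 log units; beyond the scatter).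

Compound 4, `O=C(NCCCCc1ccccc1)c1cccc(C2SCC(=O)N2c2cccc(F)c2)c1`, has not yet been measured in this assay. It differs from compound 3 in one place: 3-fluorophenyl in place of pyridin-2-yl on an amide-type nitrogen in a ring.

Within the data shown here, two measured steps bear on this. The step of no change at the digits printed from compound 1 to compound 3 (within the scatter) shows that a change of the aromatic group on the amide-type nitrogen in the ring left the solubility where it was, even for a large difference in size. The step of a 2.5-fold lower number from compound 2 to compound 3 (0.40 log units; beyond the scatter), a change at the far end of the chain, moved the number modestly. The present change is at the same place as the first step but smaller than it. A step within the scatter, or at most a modest downward one, is therefore expected: a 1.7-fold lower number from compound 3 to compound 4 (0.22 log units; within the scatter). Compound 4 is estimated to give 12000 nM, in a range from 5000 nM to 30000 nM.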

Compound 4, solubility: 10000 nM
Compound 4: the middle estimate sits 1.2-fold (0.08 log units) above what was measured; measured number inside the range.
By their numbers in this assay, from the lowest: compounds 4, 1 and 3 (each within the scatter of the next); then compound 2.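

In this assay the exchange of pyridin-2-yl for 3-fluorophenyl on the amide-type nitrogen in the ring gives a 2.0-fold lower number from compound 3 to compound 4 (0.30 log units; within the scatter), although the entering group has a carbon-only ring and no hydrogen-bond acceptor, while the leaving group has one. The position now carries a third aromatic group, and replacing 1H-1,2,3-triazol-4-yl with fluoro on the aromatic carbon gives a 2.0-fold lower number from compound 1 to compound 4 (0.30 log units; within the scatter), so this read-out does not separate compounds 1, 3 and 4 beyond the scatter, even though the step between the last two lands at its edge. Nothing shown explains why these groups sit so close, as no independent measurement bears on this result.

As far as these compounds go, it remains open whether an amine or a carboxylic acid in place of fluoro on this phenyl ring would give a step beyond the scatter, which none of the groups at this position has yet done. Among these compounds, also open is whether 1H-pyrazol-1-yl at the end of the chain, the one change here with a step beyond the scatter, would give a similar step alongside 3-fluorophenyl.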